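The source may report more compounds than this note shows. Statements on the series, on what has been measured and on what is new or still open speak of the compounds shown alone.

Measured so far in a toxicity assay on MT4 cells (Homo sapiens) for cytotoxicity, read by MTT assay, with a stated time of 5 days; a lower number here means that less compound is tolerated, a higher number that more compound is tolerated:
compound 1 `Cc1cnc(Nc2ccc(C#N)cc2)nc1Nc1c(F)cc(-c2ccco2)cc1F`, 8100 nM
compound 2 `Cc1cnc(Nc2ccc(C#N)cc2)nc1Nc1c(F)cc(-c2cncc(C#N)c2)cc1F`, 50000 nM
compound 3 `Cc1cc(-c2cncnc2)cc(C)c1Nc1ccnc(Nc2ccc(C#N)cc2)n1`, 6800 nM

Compound 3 stands lowest of the three numbers; its nearest neighbour is compound 1, within the scatter, and compound 2 lies furthest from it, beyond the scatter. Compound 4 `Cc1ncc(-c2cc(C)c(Nc3ccnc(Nc4ccc(C#N)cc4)n3)c(C)c2)cn1` differs from compound 3 by methyl in place of hydrogen on an aromatic carbon. Within the data shown here, the only measured step, a 6.2-fold higher number from compound 1 to compound 2 (0.79 log units; beyond the scatter), concerns a different replacement and does not bear directly on a methyl in place of hydrogen; no measured pair shows this change. With nothing pointing either way, no step beyond the scatter is expected in this assay. Compound 4 is estimated at 7000 nM, range 3000 nM to 20000 nM, an expected step of a 1.0-fold higher number from compound 3 to compound 4 (0.01 log units; within the scatter).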

Compound 4, half-maximal cytotoxic concentration: 3900 nM
The estimate for compound 4 lay 1.8-fold (0.25 log units) above the measured number; the range from low to high includes it.
By their numbers in this assay, from the lowest: compounds 4, 3 and 1 (each within the scatter of the next, the first and the last beyond it); then compound 2.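

Among these compounds, in the cytotoxicity series (this assay), the step from pyrimidin-5-yl to 2-methylpyrimidin-5-yl (a 1.7-fold lower number from compound 3 to compound 4 (0.24 log units; within the scatter)) gives the first direct reading of methyl in place of hydrogen on this aromatic carbon between two ring nitrogen atoms. At this position, the added methyl produces no step beyond the scatter. No available evidence accounts for the result.

The compounds shown compare only hydrogen and methyl at this carbon. On these data alone, whether an amine or a longer chain there would also stay within the scatter remains open.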